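Chloro for fluoro on the anilino ring of compound 2

This account rests on a few compounds, and the source may have more. Where it says the series, first, only, none or still open, it means among the compounds named here.

Measured compounds:
compound 1, `COC(=O)c1c(Nc2ccc(C)cc2)sc(C(=O)c2ccc(OC)cc2)c1C`, reported only as "not active" (no number reported), with no number;
compound 2, `COC(=O)c1c(Nc2ccc(F)cc2)sc(C(=O)c2ccc(OC)cc2)c1C`, 5.28%.

Within the data shown here, compound 2 holds the only number in a functional assay, with a stated time of 150 min, tested at 5 ug/mL (a higher number here means a stronger effect of the compound at the concentration tested, a lower number a weaker effect), and that number is small; compound 1 stands beside it without a number of its own, so the two show no ordering that can be read. Compound 3, `COC(=O)c1c(Nc2ccc(Cl)cc2)sc(C(=O)c2ccc(OC)cc2)c1C`, differs from compound 2 by a single change: chloro in place of fluoro on an aromatic carbon. Among the measured compounds shown here, no step between measured compounds is available to gauge what this exchange does, and compound 1, which is not active, carries a different group at the same place. Compound 2 already sits near the bottom of the scale in this assay, so the step from it to compound 3 is expected to stay within the scatter, in no clear direction. For compound 3 the estimate is 6%, with a range from 0% to 18%, the expected step being a number 0.7 percentage points higher from compound 2 to compound 3 (within the scatter).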

Compound 3, a percentage reported as activity, at one concentration (the size of the read-out at that concentration, not a potency): "not active" (no number reported)
No number was reported for compound 3, and the estimate cannot be compared.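

Among these compounds, compound 3 carries no number in this assay, so no step from compound 2 to it can be read. Nothing shown bears on this result. The compounds shown leave open whether chloro in place of fluoro changes the effect in this assay at all.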